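The source may hold more compounds than are shown below. What is called first, only, known or untested is meant among the compounds shown, and "the series" means these compounds.

Measured so far in an ADME assay on Huh-7 cells (Homo sapiens) for cytotoxicity; a lower number here means that less compound is tolerated, a higher number that more compound is tolerated:

Compound 1, `Cc1ccccc1CNc1nn(-c2ccc(F)cc2F)cc1CNCCN1CCN(C)CC1`, gives > 20000 nM in this assay.
Compound 2, `Cc1c(CNCCN2CCN(C)CC2)c(-c2ccccc2)nn1-c1ccc(F)cc1`, gives > 20000 nM in this assay.
Compound 3, `CCCN1CCC(CNCc2cn(-c3ccc([N+](=O)[O-])cc3)nc2-c2ccc(C(F)(F)F)cc2)CC1`, gives 2300 nM in this assay.

For compound 1 the reading of > 20000 nM is a limit of this assay rather than a number. For compound 2 the reading of > 20000 nM is likewise a limit. Among the measured compounds shown here, compound 3 is the one that gives a number, 2300 nM in this assay. Compound 1 thus stands at the limit of > 20000 nM in this assay, at which 2 of the 3 values shown sit, so nothing places it relative to compound 2, and compound 3 is tolerated less than the limit.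

Compound 4, `CN1CCN(CCNCc2cn(-c3ccc(F)cc3F)nc2-c2ccccc2)CC1`, is not yet measured. Going from compound 1 to compound 4 means (phenyl in place of (2-methylbenzyl)amino on an aromatic carbon). For the measured compounds named here, no two measured compounds differ in one place, so no measured step guides this change. The step of a number no higher from compound 1 to compound 4 (the limit leaves the size open) is expected to be none beyond the scatter, because compound 1 sits at the limit of > 20000 nM in this assay, at which 2 of the 3 values shown sit. Compound 4 is therefore estimated at 20000 nM in this assay, within a range from 8000 nM to 50000 nM, most likely reported again as a limit.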

Compound 4, half-maximal cytotoxic concentration: > 20000 nM
Compound 4: no number, only a limit; the forecaster's own chance of this, stated with the estimate: 70%; the middle value lies on the limit itself.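

Compound 4, like compound 1, gives only a limit of the assay and not a number, so no step between the two can be read in this assay: the limit of > 20000 nM in this assay, at which 3 of the 4 values shown sit.

The compounds shown leave open whether phenyl in place of (2-methylbenzyl)amino changes how much compound is tolerated.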